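The source may report more compounds than this note shows. Statements on the series, on what has been measured and on what is new or still open speak of the compounds shown alone.

Measured compounds:
compound 1, `CCO[C@]1(c2ccc(OCc3c(-c4c(Cl)cccc4Cl)noc3C3CC3)cc2Cl)C[C@H](c2cccc(C(=O)O)c2)C1` — 89%
compound 2, `CC(C)n1nc(C(=O)O)cc1C1CC1c1ccc(OCc2c(-c3c(Cl)cccc3Cl)noc2C2CC2)cc1Cl` — 81%
compound 3, `Clc1cc(OCc2c(-c3c(Cl)cccc3Cl)noc2C2CC2)ccc1C1CC1c1ccc(-c2nnn[nH]2)nc1` — 79%

In an assay on HEK293 cells for agonist activity at Bile acid receptor (Homo sapiens) (a lower number here means a smaller maximal response, a higher number a larger maximal response), compound 1 gives 89%, and the values of compound 2 and compound 3 both lie within the usual scatter of that number, so the three compounds cannot be told apart on this read-out. Compound 4, `O=C(O)c1cccc([C@H]2C[C@](O)(c3ccc(OCc4c(-c5c(Cl)cccc5Cl)noc4C4CC4)cc3Cl)C2)c1`, differs from compound 1 by a single change: hydrogen in place of ethyl on an oxygen on a saturated carbon. Among the compounds with values here, no measured pair changes this part of the molecule. Within the data shown here, the only measured step, a number 2 percentage points lower from compound 2 to compound 3 (within the scatter), concerns a different position on the shared core and stayed within the scatter, so it offers no guide to the present change beyond showing that the maximal response has so far been insensitive to substitution. Compound 4 is therefore expected to stay close to compound 1, with a number 4 percentage points lower from compound 1 to compound 4 (within the scatter) amounting to no step beyond the scatter. The estimate for compound 4 in this assay is 85%, ranging from 70% to 98%.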

Compound 4, largest response reached (reported as efficacy), in percent of the reference or control that the assay uses: 79%
Estimate against measurement, compound 4: 6 percentage points above; measured number inside the range.
By their numbers in this assay, from the lowest: compounds 3, 4, 2 and 1 (each within the scatter of the next).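

Within the data shown here, the pair gives the first measured reading at this position: with hydroxy in place of ethoxy on the saturated ring carbon, this assay shows a number 10 percentage points lower from compound 1 to compound 4 (within the scatter). Compound 1 and compound 4 therefore cannot be told apart on maximal response, so in this pair the ethyl on that oxygen is not needed to keep the response within the scatter. Nothing available bears on why this is so.

From the compounds shown here alone, it remains open whether an amine or a longer chain such as propoxy on this carbon would keep the maximal response in the same range. Going by these compounds, it is also open whether compound 1 and compound 4 differ on any read-out other than maximal response.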